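The source may report more compounds than this note shows. Statements on the series, on what has been measured and on what is new or still open speak of the compounds shown alone.

Working notes on the series. Among the compounds with values here, in a functional assay on HL-60 cells (Homo sapiens) for inhibition, read by MTT assay (a higher number here means a weaker inhibitor, a lower number a stronger inhibitor), compound 1 (`CC1(C)C2CCC1(C)C(OC(=O)/C=C/c1cc(O)c(O)c(Br)c1)C2`) gives 15200 nM, the higher of the two numbers so far and so the weaker inhibitor. Compound 2 (`O=C(/C=C/c1cc(O)c(O)c(Cl)c1)OCCc1ccccc1`) gives 7010 nM, a gap beyond the usual scatter. Not yet measured is compound 3 (`CC1(C)C2CCC1(C)C(OC(=O)/C=C/c1cc(O)c(O)c(Cl)c1)C2`), which keeps the core of compound 1 and changes one substituent: chloro in place of bromo on an aromatic carbon, ortho to a hydroxy group, meta to a hydroxy group and meta to a large group. Within the data shown here, no measured pair isolates this exchange. Compound 2 also carries chloro and gives 7010 nM, but it differs from compound 1 elsewhere as well, so it sets no size for the change. Swapping one halogen for the other is therefore expected to give a small step in this assay, within the scatter, if anything toward a lower number. The estimate amounts to an expected step of a 1.3-fold lower number from compound 1 to compound 3 (0.10 log units; within the scatter). For compound 3 the estimated value is 12000 nM, with an expected range of 6000 nM to 24000 nM.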

Compound 3, half-maximal inhibitory concentration: 18600 nM
The estimate for compound 3 lay 1.6-fold (0.19 log units) below the measured number; the measured number falls inside the stated range.
By their numbers in this assay, from the lowest: compound 2; then compounds 1 and 3 (each within the scatter of the next).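

The exchange of bromo for chloro on an aromatic carbon, ortho to a hydroxy group and meta to a hydroxy group, now has a size of its own: in this assay the step is a 1.2-fold higher number from compound 1 to compound 3 (0.09 log units; within the scatter), so on the core of compound 1 the two halogens are not told apart at this position. Within the data shown here, the values of the earlier compounds could not show this, since the only other chloro compound differs from compound 1 elsewhere as well; with chloro held fixed, compound 3 gives 18600 nM and compound 2 gives 7010 nM, so the change away from this position is the one that separates those two values. Nothing on hand offers an explanation for the halogen result.

The compounds shown carry only bromo or chloro here, so it stays open whether fluoro, methoxy or an amine at this position would depart from these numbers. Also open is whether the exchange stays as small with compound 2 as its partner, since the bromo counterpart of compound 2 is not among the compounds shown.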